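The source may report more compounds than this note shows. Statements on the series, on what has been measured and on what is new or still open speak of the compounds shown alone.

Values so far in an ADME assay on microsomes from liver (Homo sapiens) for metabolic stability; a higher number here means that the compound lasts longer, a lower number that the compound disappears faster

Compound 1 `CCC(CC)(c1nnc[nH]1)c1ccc(-c2ccc3cc(F)cc(F)c3c2)[nH]c1=O` gives 1.76 h
Compound 2 `CC(C)C(c1ccc(-c2ccc3cccc(F)c3c2)[nH]c1=O)N1CCCCS1(=O)=O` gives 0.373 h
Compound 3 `CC(C)C(Nc1nnc[nH]1)c1ccc(-c2ccc3cccc(F)c3c2)[nH]c1=O` gives > 3 h

Compound 1 gives 1.76 h, and compound 2 gives 0.373 h, so compound 1 holds the higher of the two exact numbers. Compound 3 stands at > 3 h, which is a limit of this assay and not an exact number.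

The next compound to consider is compound 4 `CCC(CC)(c1nnc[nH]1)c1ccc(-c2ccc3cccc(F)c3c2)[nH]c1=O`. It differs from compound 1 in one place: hydrogen in place of fluoro on an aromatic carbon. Put simply, hydrogen stands in place of fluoro on an aromatic carbon.

For the measured compounds named here, the only measured step is an at least 8.0-fold higher number from compound 2 to compound 3 (0.90 log units; beyond the scatter), which lies beyond the scatter. That step swaps a different group, on a saturated chain carbon, so it says how much that group can matter and nothing direct about this fluoro group. Going by the values given here, no measured pair isolates the change made here.

The best starting point is therefore compound 1 itself, at 1.76 h, with no clear direction of change to build in. The expected 1.2-fold lower number from compound 1 to compound 4 (0.07 log units; within the scatter) is none beyond the scatter. For compound 4 the estimated half-life is 1.5 h, with an expected range from 0.7 h to 3 h.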

Compound 4, half-life: 1.19 h
The estimate for compound 4 lay 1.3-fold (0.10 log units) above the measured number; the measured number falls inside the stated range.
By their numbers in this assay, from the lowest: compound 2; then compounds 4 and 1 (each within the scatter of the next). At a limit, above all of these: compound 3.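

In this assay, hydrogen in place of fluoro on this aromatic carbon, which is meta to a fluoro group and para to a fused ring, gives a 1.5-fold lower number from compound 1 to compound 4 (0.17 log units; within the scatter), a step too small to separate the two compounds. The earlier compounds shown here offered only a change on a saturated chain carbon, an at least 8.0-fold higher number from compound 2 to compound 3 (0.90 log units; beyond the scatter), and said nothing about the fluoro groups on the aromatic ring; this pair shows that, with the rest of compound 1 unchanged, the half-life does not move beyond the scatter when this fluoro group is exchanged for hydrogen. Nothing shown here gives a reason for so small a step.

As far as these compounds go, only fluoro and hydrogen have been compared at this position, so it remains open whether a larger group on the same carbon, such as chloro, methyl or a nitrile, would shift the half-life. From the compounds shown here alone, it is also open whether the same exchange would stay this small in a compound with a different group on the saturated chain carbon, or what replacing the remaining fluoro group would do.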